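Thiophen-3-yl in Place of Thiophen-2-yl on Compound 1

The source may report more compounds than this note shows. Statements on the series, on what has been measured and on what is new or still open speak of the compounds shown alone.

Three compounds have been measured in a functional assay on cells (Leukemia cell, Homo sapiens) for inhibition; a lower number here means a stronger inhibitor of growth, a higher number a weaker inhibitor of growth:

Compound 1, `N=C(N)N/N=C/c1c(-c2cccs2)nc2n1CCS2`, gives 18600 nM.
Compound 2, `N=C(N)N/N=C/c1c(-c2cccs2)nc2sccn12`, gives 6760 nM.
Compound 3, `N=C(N)N/N=C/c1c(-c2ccsc2)nc2sccn12`, gives 6920 nM.

Compound 1 stands at the highest number of the three, so it is the weakest inhibitor of growth here; its gap to compound 2 and to compound 3 lies beyond the scatter of the measurement. Compound 2 and compound 3 share a core and differ only in the thiophene; that step, a 1.0-fold higher number from compound 2 to compound 3 (0.01 log units; within the scatter), is within the scatter.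

Compound 4, `N=C(N)N/N=C/c1c(-c2ccsc2)nc2n1CCS2`, is made from compound 1 by the change (thiophen-3-yl in place of thiophen-2-yl on an aromatic carbon). Among the compounds with values here, the only measured step that bears on it is the one from compound 2 to compound 3, the same swap of thiophene on a related core, which changed nothing beyond the scatter. The step to compound 4 is therefore expected to be small, no change at the digits printed from compound 1 to compound 4 (within the scatter), with no clear direction. Compound 4 is estimated at 18600 nM, within the range 9000 nM to 38000 nM.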

Compound 4, concentration for 50% growth inhibition: 19100 nM
Compound 4: middle estimate off by 1.0-fold (0.01 log units), on the low side, and the stated range covers the measured number.
By their numbers in this assay, from the lowest: compounds 2 and 3 (each within the scatter of the next); then compounds 1 and 4 (each within the scatter of the next).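

On the core of compound 1, thiophen-3-yl in place of thiophen-2-yl gives, in this assay, a 1.0-fold higher number from compound 1 to compound 4 (0.01 log units; within the scatter), so the two groups cannot be told apart on this core. Before this result, the swap had been read on only one core; it now has a reading on a second core, and the two readings agree: the same change on two cores in this assay, a 1.0-fold higher number (0.01 log units; within the scatter) from compound 2 to compound 3 and a 1.0-fold higher number (0.01 log units; within the scatter) from compound 1 to compound 4, 1.0-fold (0.00 log units) apart, within the scatter of two such steps Across these two pairs, then, the point at which the thiophene is joined to this aromatic carbon makes no difference that the measurement can detect.

Among the compounds shown, this aromatic carbon carries only these two thiophene groups. As far as these compounds go, what a phenyl ring, a furan ring, an amine or a longer alkyl chain would give at this place remains open.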